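Predicting Compound 4 from Three Close Analogues

The source may report more compounds than this note shows. Statements on the series, on what has been measured and on what is new or still open speak of the compounds shown alone.

Measured compounds in a functional assay on A-431 cells (Homo sapiens) for cytotoxicity, read by MTT assay, with a stated time of 24 h; a lower number here means a stronger inhibitor, a higher number a weaker inhibitor:
compound 1 `COc1ccc(/C=C\C(=O)O)c(OCc2cn(-c3cccc(C#N)c3)nn2)c1CC=C(C)C`, 22900 nM
compound 2 `COc1ccc(/C=C\C(=O)O)c(OCc2cn(-c3ccc(CO)cc3)nn2)c1CC=C(C)C`, 16400 nM
compound 3 `COc1ccc(/C=C\C(=O)O)c(OCc2cn(-c3ccccc3I)nn2)c1CC=C(C)C`, 32700 nM

Compound 3 has the highest of the three numbers, yet its steps to the others are small: a 1.4-fold higher number from compound 1 to compound 3 (0.15 log units; within the scatter) and a 2.0-fold higher number from compound 2 to compound 3 (0.30 log units; within the scatter). Likewise, a 1.4-fold lower number from compound 1 to compound 2 (0.14 log units; within the scatter). All three values therefore sit together within the usual scatter.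

Compound 4 `COc1ccc(/C=C\C(=O)O)c(OCc2cn(-c3nc4ccccc4s3)nn2)c1CC=C(C)C` is not yet measured. It differs from compound 3 by 1,3-benzothiazol-2-yl in place of 2-iodophenyl on an aromatic nitrogen. Every measured step on this same aromatic nitrogen, exchanging one aryl group for another, stayed within the scatter, so no step beyond the scatter is expected in this assay for this change either. Compound 4 is estimated at 25000 nM, with a range from 8000 nM to 80000 nM, which means an expected step of a 1.3-fold lower number from compound 3 to compound 4 (0.12 log units; within the scatter).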

Compound 4, half-maximal inhibitory concentration: 20800 nM
Compound 4: the middle estimate sits 1.2-fold (0.08 log units) above what was measured, and the stated range covers the measured number.
By their numbers in this assay, from the lowest: compounds 2, 4, 1 and 3 (each within the scatter of the next).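

In this assay the step of a 1.6-fold lower number from compound 3 to compound 4 (0.20 log units; within the scatter) is joined by a 1.3-fold higher number from compound 2 to compound 4 (0.10 log units; within the scatter) and by a 1.1-fold lower number from compound 1 to compound 4 (0.04 log units; within the scatter) on this aromatic nitrogen. 1,3-Benzothiazol-2-yl is the only group shown here with a five-membered aromatic ring with 2 hetero atoms, so the flat response at this position now reaches beyond substituted phenyl groups. No available measurement bears on why the response is so flat at this position.

From the compounds shown here alone, it remains open whether a simple amine or a longer alkyl chain on this nitrogen, in place of an aromatic group, would give a step beyond the scatter.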